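The compounds below may be only part of what the source reports. "The series", "measured", "known", "first", "only" and "open" are said of these compounds alone.

Compound 1, with the structure `Fc1ccc(-c2nn3c(NC4CCCC4)cccc3c2-c2cccnc2)cc1`, was tested in an ADME assay on Vero cells (Chlorocebus sabaeus) for cytotoxicity; a higher number here means that more compound is tolerated, a lower number that less compound is tolerated. In this assay compound 1 gives > 40000 nM, which is a limit of the assay rather than a measured number. Compound 2, of structure `Nc1nc(-c2c(-c3ccc(F)cc3)nn3c(NC4CCCC4)cccc23)cs1`, has no result in this assay: "not determined" (no result reported). So for compound 1 only a limit is known, and the one other entry gives no number either; the sole point of reference is the limit of > 40000 nM in this assay, at which 1 of the 2 values shown sits. Compound 3, with the structure `Fc1ccc(-c2nn3c(NC4CCCC4)cccc3c2-c2ccncc2)cc1`, differs from compound 1 in one place: pyridin-4-yl in place of pyridin-3-yl on an aromatic carbon. Within the data shown here, no pair of measured compounds shows what such a change does in this assay, so the expected step is a step that the limit leaves unreadable from compound 1 to compound 3, meaning none beyond the usual scatter. Compound 3 is therefore estimated to give 50000 nM in this assay, within a range from 20000 nM to 120000 nM, and most likely the assay will again report only a limit for it.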

Compound 3, half-maximal cytotoxic concentration: 20000 nM
Estimate against measurement, compound 3: 2.5-fold (0.40 log units) above, and the stated range covers the measured number.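

In this assay compound 3 gives 20000 nM, the only single number among the compounds shown, so with pyridin-4-yl on this aromatic carbon the read-out falls within the range the assay can measure. The change from pyridin-3-yl to pyridin-4-yl gives an at least 2.0-fold lower number from compound 1 to compound 3 (0.30 log units; that floor lies within the scatter), so these two values alone do not establish that moving the ring nitrogen matters. That step is only a floor because compound 1 stands at a limit: the limit of > 40000 nM in this assay, at which 1 of the 3 values shown sits.

As far as these compounds go, how large the true gap between the two pyridines is in this assay remains open, since it could be small or much larger than the floor. Also open, from the compounds shown here alone, is what pyridin-2-yl, a plain phenyl or an aminomethyl group would give on the same aromatic carbon.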